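Double-Bond Geometry Tested Against Cell Growth

The source may hold more compounds than are shown below. What is called first, only, known or untested is meant among the compounds shown, and "the series" means these compounds.

Measured compounds:
Compound 1 `C#CCOc1ccc(/C=C/C(=O)c2ccc(CC=C(C)C)cc2)cc1OC` — in a functional assay on CCRF-CEM cells (Homo sapiens) for cytotoxicity, with a stated time of 72 h (a lower number here means a stronger inhibitor, a higher number a weaker inhibitor), compound 1 gives > 50000 nM, which is a limit of the assay.
Compound 2 `C=CCOc1ccc(/C=C/C(=O)c2ccc(OCC=C(C)C)c(CC=C)c2)cc1OC` — in this assay compound 2 gives > 50000 nM, again a limit rather than a number.

Among the compounds with values here, compound 2 therefore stands only as a limit, and the one further value shown is a limit as well; both sit at the limit of > 50000 nM in this assay, at which 2 of the 2 values shown sit. The account follows the step from compound 2 to compound 3 `C=CCOc1ccc(/C=C\C(=O)c2ccc(OCC=C(C)C)c(CC=C)c2)cc1OC`, a pair that shares every atom and bond: the two compounds have the same atoms and bonds and differ only in configuration as drawn: 1 of 1 stereo elements differ; a double bond is drawn E in compound 2 and Z in compound 3. Within the data shown here, no step between measured compounds is available to set a scale. With compound 2 at the limit, no step beyond the usual scatter is expected in this assay in either direction. Compound 3 is expected to stay at the limit, with an estimate of 50000 nM and a range from 20000 nM to 150000 nM. This estimate implies a step of a number no higher from compound 2 to compound 3 (the limit leaves the size open), expected to be essentially none.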

Compound 3, half-maximal inhibitory concentration: > 50000 nM
Compound 3: no number, only a limit; the forecaster's own chance of this, stated with the estimate: 85%; the middle value lies on the limit itself.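

Compound 3, like compound 2, gives only a limit in this assay, so no step can be read between the two, which differ only in double-bond geometry: the fact that compounds 2 and 3 differ only in the configuration as drawn

What the compounds shown leave open is whether that geometry matters at all for cell growth, since every value sits at the same limit: the limit of > 50000 nM in this assay, at which 3 of the 3 values shown sit.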